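Saturating a Chain Alkene Across Two Cores

This account rests on a few compounds, and the source may have more. Where it says the series, first, only, none or still open, it means among the compounds named here.

Compound 1, `COc1cc(CNC(=O)CCCCCCC(C)C)ccc1OC(=O)c1ccc(C(N)=S)cc1`, gives > 50000 nM in a functional assay on K562 cells (Homo sapiens) for antiproliferative activity, read by MTT assay, with a stated time of 48 h; on this read-out lower numbers stand for stronger inhibition and higher numbers for weaker inhibition; this value is a limit of the assay, not a number.
Compound 2, `COc1cc(CNC(=O)CCCC/C=C/C(C)C)ccc1OC(=O)c1ccc(C(N)=S)cc1`, gives > 50000 nM in this assay; this too is a limit.
Compound 3, `COc1cc(CNC(=O)CCCC/C=C/C(C)C)ccc1OCCCCCOc1ccc(C(N)=S)cc1`, gives > 50000 nM in this assay; again a limit.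

All three measured compounds therefore sit at the limit of > 50000 nM in this assay, at which 3 of the 3 values shown sit, so none of them shows measurable inhibition of cell growth here. The change from compound 2 to compound 1 is isopentyl in place of 3-methylbut-1-en-1-yl on a saturated chain carbon, four bonds along the chain from a carbonyl carbon, and its effect is a step that the two limits leave unreadable from compound 2 to compound 1, because both ends of the comparison rest on (the limit of > 50000 nM in this assay, at which 3 of the 3 values shown sit). Compound 3 shares the chain of compound 2 but carries a different core; how the two cores differ is not broken down here.

Compound 4, `COc1cc(CNC(=O)CCCCCCC(C)C)ccc1OCCCCCOc1ccc(C(N)=S)cc1`, is not yet measured. It arises from compound 3 by isopentyl in place of 3-methylbut-1-en-1-yl on a saturated chain carbon, four bonds along the chain from a carbonyl carbon, which is the same change that turns compound 2 into compound 1, placed on the same kind of chain carbon. The earlier instance of this change is unreadable, and its two partners both sit at the limit, so there is no step size to carry over; the expectation for compound 4 rests on compound 3 sitting at the limit of > 50000 nM in this assay, at which 3 of the 3 values shown sit, and on compound 1 doing the same. Compound 4 is therefore expected to remain at or near the limit, which is an expected step that the limit leaves unreadable from compound 3 to compound 4. The estimate for compound 4 is 80000 nM, expected to lie between 30000 nM and 300000 nM.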

Compound 4, half-maximal inhibitory concentration: > 50000 nM
Compound 4: a limit, no number; the forecaster's own chance of this, stated with the estimate: 85%; the middle value is on the limit's open side.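

No step size can be read from compound 3 to compound 4, because both compounds rest on a limit of the assay rather than a number: the limit of > 50000 nM in this assay, at which 4 of the 4 values shown sit.

The compounds shown leave open whether isopentyl in place of 3-methylbut-1-en-1-yl changes growth inhibition at all on either core in this assay, and which structural feature could bring a compound to a measurable value.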